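Changing the group on the sulfonyl sulfur of compound 1

A few compounds are considered here, and "the series" means these few. Any claim that something is new, unique, unknown or untested is made for them only; others in the source may bear on it.

Measured so far in an ADME assay on HEK293 cells (Homo sapiens) for cytotoxicity, read by resazurin assay, with a stated time of 48 h; a higher number here means that more compound is tolerated, a lower number that less compound is tolerated:
- Compound 1 `Cc1ccc(S(=O)(=O)Nc2ccc(-c3nc4ccccc4o3)cc2)cc1` gives 88000 nM
- Compound 2 `Cc1ccc(S(=O)(=O)Nc2ccc3oc(-c4ccccc4)nc3c2)cc1` gives 75000 nM
- Compound 3 `C=Cc1ccc(S(=O)(=O)Nc2ccc3oc(-c4ccccc4)nc3c2)cc1` gives 53000 nM
- Compound 4 `O=S(=O)(Nc1ccc(-c2nc3ccccc3o2)cc1)c1cccc(Cl)c1` has not been measured yet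

Compound 1 (88000 nM) sits within the scatter of both compound 2 (75000 nM) and compound 3 (53000 nM), so these three numbers cannot be told apart in this assay with any confidence.

Compound 4 keeps the core of compound 1 and changes one group (3-chlorophenyl in place of 4-methylphenyl on a sulfonyl sulfur): 3-chlorophenyl in place of 4-methylphenyl on a sulfonyl sulfur. Within the data shown here, no measured compound carries a 3-chlorophenyl group, so the data hold no direct precedent. Among the measured compounds shown here, the one measured step that comes close is a 1.4-fold lower number from compound 2 to compound 3 (0.15 log units; within the scatter) where vinyl replaces methyl on an aromatic carbon, on a core other than that of compound 1. That step stays within the scatter, and it is a thin guide. A slight drift towards a lower number is the most that can be expected, with no change beyond the scatter. The estimated step is a 1.3-fold lower number from compound 1 to compound 4 (0.10 log units; within the scatter) and it rests on that single neighbouring step. In this assay compound 4 is expected at 70000 nM with an estimated range from 35000 nM to 130000 nM as its likely span.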

Compound 4, half-maximal cytotoxic concentration: > 100000 nM
Compound 4 gave a limit, no number; the forecaster's own chance of this, stated with the estimate: 20%; middle value at least 1.4-fold (0.15 log units) away from the limit.
By their numbers in this assay, from the lowest: compounds 3, 2 and 1 (each within the scatter of the next). At a limit, above all of these: compound 4.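

In this assay compound 4 gives > 100000 nM, which is a limit of the assay and not a number. Among these compounds, putting 3-chlorophenyl in place of 4-methylphenyl on the sulfonyl sulfur gives an at least 1.1-fold higher number from compound 1 to compound 4 (0.05 log units; that floor lies within the scatter), so this position on the core of compound 1 accepts the new ring with no sign that less compound is tolerated, while the true size of the step stays unknown. The earlier compounds showed a change in this part of the molecule only as vinyl in place of methyl on another core, and none of them stood at the limit: the limit of > 100000 nM in this assay, at which 1 of the 4 values shown sits.

The compounds shown do not separate what the chlorine contributes from what removing the methyl contributes, and a plain phenyl on the sulfonyl sulfur would be needed to tell those two apart. They also leave open whether this position stays as well tolerated when it carries something other than a chlorine or a small carbon group, such as an amine or a carboxylic acid on the ring, or a simple alkyl chain in place of the ring.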